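Sulfamoyl for Carbamoyl on a Piperidine Sulfonamide Core

This account rests on a few compounds, and the source may have more. Where it says the series, first, only, none or still open, it means among the compounds named here.

Measured compounds in a functional assay on BXPC-3 cells (Homo sapiens) for inhibition, read by MTT assay, with a stated time of 7 days; a higher number here means a weaker inhibitor, a lower number a stronger inhibitor:
compound 1 , `CCN(CC)C(=O)c1ccc(S(=O)(=O)N2CCC[C@@H](C(=O)N3CCC(F)(F)CC3)C2)cc1`, gives 240 nM
compound 2 , `CCN(CC)S(=O)(=O)c1ccc(S(=O)(=O)N2CCC[C@@H](C(=O)N3CCOCC3)C2)cc1`, gives 790 nM
compound 3 , `CCN(CC)S(=O)(=O)c1ccc(S(=O)(=O)N2CCC[C@@H](C(=O)N3CC[C@H](OC)C3)C2)cc1`, gives 6750 nM

Compound 1 has the lowest of the three numbers in this assay. Compound 2 sits nearest to it, and compound 3 is the furthest away. Among the measured compounds shown here, the only step between neighbours that differ in one place is an 8.5-fold higher number from compound 2 to compound 3 (0.93 log units; beyond the scatter), which concerns the amide side of the core and not the aryl substituent.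

Compound 4, `CN(C)S(=O)(=O)c1ccc(S(=O)(=O)N2CCC[C@@H](C(=O)N3CCC(F)(F)CC3)C2)cc1`, differs from compound 1 in one place: dimethylsulfamoyl in place of diethylcarbamoyl on an aromatic carbon. For the measured compounds named here, no measured step covers this exchange. Compound 2 and compound 3 both carry a sulfamoyl group on the aromatic ring and show higher numbers than compound 1, but each also differs from compound 1 at the amide, so their values cannot be assigned to the aryl change alone. The data therefore leave the direction open; a modest weakening is a reasonable expectation, since every sulfamoyl-bearing compound here is weaker than compound 1, which gives 240 nM. Compound 4 is thus expected to give 500 nM in this assay, within 150 nM to 1700 nM, an expected step of a 2.1-fold higher number from compound 1 to compound 4 (0.32 log units; beyond the scatter).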

Compound 4, half-maximal inhibitory concentration: 560 nM
Beside the measured number, compound 4's estimate is 1.1-fold (0.05 log units) below it, within the range that was stated.
By their numbers in this assay, from the lowest: compound 1; then compounds 4 and 2 (each within the scatter of the next); then compound 3.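

Among the compounds shown here, with the rest of compound 1 held constant, this assay gives a 2.3-fold higher number from compound 1 to compound 4 (0.37 log units; beyond the scatter) when dimethylsulfamoyl replaces diethylcarbamoyl on the aromatic carbon para to a large group, which is the first reading of this position on its own. The step is modest but beyond the scatter, so the sulfamoyl group is accepted here with a limited loss, and the sulfamoyl-bearing compound 4 stays on the same side of the comparison as the earlier sulfamoyl compounds, now without any change at the amide. The exchange alters the linking group and the alkyl substituents together, so this single step cannot divide the loss between them, and nothing in the data offered accounts for the step.

Dimethylcarbamoyl or diethylsulfamoyl on the core of compound 1 would separate those two changes, and it remains open how far the alkyl substituents on the nitrogen matter at this position. Also open, as far as these compounds go, is how a smaller or differently built group at the same aromatic carbon, such as an unsubstituted sulfonamide, a nitrile or a carboxylic acid, would read in this assay.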